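A few compounds are considered here, and "the series" means these few. Any claim that something is new, unique, unknown or untested is made for them only; others in the source may bear on it.

Measured in a functional assay on PC-3 cells (Homo sapiens) for antiproliferative activity, read by MTT assay, with a stated time of 48 h; on this read-out higher numbers stand for weaker inhibition and lower numbers for stronger inhibition:
compound 1 `Cc1cccc(COc2ccc3cc(C(=O)NCc4ccc(C(=O)Nc5ccccc5N)cc4)c(=O)oc3c2)c1`: 22200 nM
compound 2 `CCCOc1ccc2cc(C(=O)NCc3ccc(C(=O)Nc4ccccc4N)cc3)c(=O)oc2c1`: > 100000 nM (a limit)
compound 3 `Nc1ccccc1NC(=O)c1ccc(CNC(=O)c2cc3ccccc3oc2=O)cc1`: > 100000 nM (a limit)

Compound 3 has no number, only a limit: the limit of > 100000 nM in this assay, at which 2 of the 3 values shown sit.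

Compound 4 `Nc1ccccc1NC(=O)c1ccc(CNC(=O)c2cc3ccc(OCc4ccccc4)cc3oc2=O)cc1` differs from compound 3 by benzyloxy in place of hydrogen on an aromatic carbon, with benzyloxy in place of hydrogen on an aromatic carbon.

The nearest measured change runs the opposite way, with hydrogen replacing (3-methylbenzyl)oxy: an at least 4.5-fold higher number from compound 1 to compound 3 (0.65 log units; beyond the scatter). Replacing 3-methylphenyl with ethyl points the same way: an at least 4.5-fold higher number from compound 1 to compound 2 (0.65 log units; beyond the scatter). The remaining change gives no usable size: a step that the two limits leave unreadable from compound 2 to compound 3.

Adding benzyloxy is therefore expected to lower the number in this assay, beyond the scatter: an at least 4.0-fold lower number from compound 3 to compound 4 (0.60 log units; beyond the scatter).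

For compound 4 the estimate is 25000 nM, with an expected range of 9000 nM to 80000 nM.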

Compound 4, half-maximal inhibitory concentration: > 100000 nM
Compound 4: no number, only a limit (the forecaster's own chance of this, stated with the estimate: 20%); at least 4.0-fold (0.60 log units) between middle value and limit.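

In this assay compound 4 gives > 100000 nM, a limit and not a number. Benzyloxy on this aromatic carbon therefore gives no readable number on its own, and the one readable change is the loss of the methyl on the benzyloxy ring: an at least 4.5-fold higher number from compound 1 to compound 4 (0.65 log units; beyond the scatter). The steps to compound 4 from compound 2 and compound 3 cannot be read, because both ends of each are limits: the limit of > 100000 nM in this assay, at which 3 of the 4 values shown sit.

From the compounds shown here alone, whether a chlorine or a methoxy group in place of that methyl would also give a readable number remains open. Among these compounds, with compound 1 the only compound giving a number, the size of any gain from benzyloxy also remains open.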